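The compounds below may be only part of what the source reports. "The series", "measured", "known", "first", "only" and "open" are said of these compounds alone.

Compound 1 `C=CC(=O)N1CCCC(n2nc(-c3ccc(Oc4ccccc4)cc3)cc2C(=O)O)C1` carries a free carboxylic acid; in a functional assay on JeKo-1 cells (Homo sapiens) for inhibition, read by luminescence and CellTiter-Glo, with a stated time of 72 h (a lower number here means a stronger inhibitor, a higher number a weaker inhibitor), compound 1 returns only a limit, > 60000 nM, as noted in the limit of > 60000 nM in this assay, at which 1 of the 3 values shown sits. Compound 3 `C=CC(=O)N1CCCC(n2nc(-c3ccc(Oc4ccccc4)cc3)cc2C(=O)OCC)C1` is its ethyl ester, and in this assay compound 3 gives 21200 nM. The change from compound 1 to compound 3 is ethyl in place of hydrogen on an oxygen next to a carbonyl group, and it produced an at least 2.8-fold lower number from compound 1 to compound 3 (0.45 log units; beyond the scatter). Compound 2 `O=C(CCl)Nc1ccc(Cn2nc(-c3ccc(Oc4ccccc4)cc3)cc2C(=O)O)cc1` is built on a different core; the difference between the two cores is not broken down here. In this assay compound 2 gives 2500 nM, the lowest number among the measured compounds and beyond the scatter from compound 3.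

Compound 4 `CCOC(=O)c1cc(-c2ccc(Oc3ccccc3)cc2)nn1Cc1ccc(NC(=O)CCl)cc1` is the ethyl ester of compound 2; the change is ethyl in place of hydrogen on an oxygen next to a carbonyl group, the same change as from compound 1 to compound 3. By analogy with that step, an ester on the core of compound 2 is expected to give a lower number than compound 2, so the step of a 2.1-fold lower number from compound 2 to compound 4 (0.32 log units; beyond the scatter) is estimated as similar in direction to the earlier one, though its size rests on a single precedent. For compound 4 in this assay the expected value is 1200 nM, estimated between 300 nM and 5000 nM.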

Compound 4, half-maximal inhibitory concentration: 400 nM
For compound 4 the middle estimate is 3.0-fold (0.48 log units) above the measured one, and the stated range covers the measured number.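

In this assay, carboxy to ethoxycarbonyl on the second core gives a 6.3-fold lower number from compound 2 to compound 4 (0.80 log units; beyond the scatter). The change therefore lowers the number on both cores shown, but these are only two cases and set no rule for the series, and whether the size of the step carries over from one core to the other remains unsettled: the same change on two cores in this assay, an at least 2.8-fold lower number (0.45 log units; beyond the scatter) from compound 1 to compound 3 and a 6.3-fold lower number (0.80 log units; beyond the scatter) from compound 2 to compound 4; the limit leaves it open whether they differ. The value of compound 1, > 60000 nM, is a limit of the assay and not a number: the limit of > 60000 nM in this assay, at which 1 of the 4 values shown sits.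

As far as these compounds go, what a methyl group or a longer chain on that oxygen, or an amine in its place, would do on either core remains open. The parts that distinguish the two cores are also not varied one at a time among the compounds shown, so the contribution of each part to the values in this assay stays open.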